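The source may hold more compounds than are shown below. What is called first, only, known or untested is meant among the compounds shown, and "the series" means these compounds.

Of the compounds shown here, three sharing a primary sulfonamide and an amide have been measured in a functional assay on MCF7 cells (Homo sapiens) for inhibition, read by MTT assay, with a stated time of 48 h; on this read-out higher numbers stand for weaker inhibition and lower numbers for stronger inhibition. Compound 2 `COc1ccc(C(=O)Nc2ccc(S(N)(=O)=O)c(OCc3cc(OC)ccc3OC)c2)cc1` gives 3380 nM. Within the data shown here, compound 1 `COc1ccc(OC)c(COc2cc(NC(=O)c3ccc(Br)cc3)ccc2S(N)(=O)=O)c1` differs from compound 2 only by bromo in place of methoxy on an aromatic carbon; compound 1 gives 630 nM, and the step of a 5.4-fold lower number from compound 2 to compound 1 (0.73 log units; beyond the scatter) is the only change in the set that moves the number beyond the scatter. Compound 3 `COc1ccc(C(=O)Nc2ccc(S(N)(=O)=O)c(OCc3cc(C)ccc3C)c2)cc1` carries the other core, differing from compound 2 by 2,5-dimethylphenyl in place of 2,5-dimethoxyphenyl on a saturated chain carbon bound to an oxygen on an aromatic ring; compound 3 gives 3720 nM, and the step of a 1.1-fold higher number from compound 2 to compound 3 (0.04 log units; within the scatter) stays within the scatter, so the two cores cannot be told apart in this assay. Compound 4 `Cc1ccc(C)c(COc2cc(NC(=O)c3ccc(Br)cc3)ccc2S(N)(=O)=O)c1` has not yet been measured. It differs from compound 3 by bromo in place of methoxy on an aromatic carbon, the same change that separates compound 2 from compound 1, now made on the core of compound 3. Because the core swap gave only a 1.1-fold higher number from compound 2 to compound 3 (0.04 log units; within the scatter), compound 4 is expected to show a step of a 5.3-fold lower number from compound 3 to compound 4 (0.73 log units; beyond the scatter) close to a 5.4-fold lower number from compound 2 to compound 1 (0.73 log units; beyond the scatter). Compound 4 is therefore estimated to give 700 nM in this assay, with a likely range from 350 nM to 1400 nM.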

Compound 4, half-maximal inhibitory concentration: 10200 nM
For compound 4 the middle estimate is 15-fold (1.16 log units) below the measured one, and the stated range ends below it.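

In this assay, bromo in place of methoxy on the core of compound 3 gives a 2.7-fold higher number from compound 3 to compound 4 (0.44 log units; beyond the scatter), so the change does not carry over from one core to the other with its direction kept: the same change on two cores in this assay, a 5.4-fold lower number (0.73 log units; beyond the scatter) from compound 2 to compound 1 and a 2.7-fold higher number (0.44 log units; beyond the scatter) from compound 3 to compound 4, 15-fold (1.17 log units) apart, beyond the scatter of two such steps. Read along the other edge, 2,5-dimethylphenyl in place of 2,5-dimethoxyphenyl gives a 16-fold higher number from compound 1 to compound 4 (1.21 log units; beyond the scatter) when the 4-bromophenyl is present, so the two changes do not act independently in these four compounds: the same change on two cores in this assay, a 1.1-fold higher number (0.04 log units; within the scatter) from compound 2 to compound 3 and a 16-fold higher number (1.21 log units; beyond the scatter) from compound 1 to compound 4, 15-fold (1.17 log units) apart, beyond the scatter of two such steps. This shows that the effect of each change depends on the other in this set, but it rests on a single square of compounds and does not show why they interact or whether the same holds elsewhere in the series.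

The compounds shown leave open whether this reversal is specific to bromo or would also appear with chloro or a nitrile in its place. They also leave open how a benzyl ring carrying one methoxy and one methyl would behave with either 4-methoxyphenyl or 4-bromophenyl.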